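Swapping the Pyrazinyl Enol for a Difluorophenyl Alkyne

This account rests on a few compounds, and the source may have more. Where it says the series, first, only, none or still open, it means among the compounds named here.

Of the compounds shown here, three sharing one core have been tested in an assay on CHO cells for displacement of a labelled ligand from adenosine receptor A1 (Homo sapiens), read by scintillation counting, with a stated time of 60 min, tested at 10 uM; a lower number here means less inhibition, a higher number more inhibition at the concentration tested (going by the name of the read-out). Compound 1 `CNC(=O)[C@@]12C[C@@H]1[C@@H](n1cnc3cnc(/C=C(\O)c4cnccn4)nc31)[C@H](O)[C@@H]2O` gives 14% in this assay, the lowest of the three numbers. Compound 2 `CNC(=O)[C@@]12C[C@@H]1[C@@H](n1cnc3c(C)nc(C#Cc4ccccc4)nc31)[C@H](O)[C@@H]2O` gives 15%, a number within the scatter of compound 1, so the two cannot be told apart. Compound 3 `CNC(=O)[C@@]12C[C@@H]1[C@@H](n1cnc3c(/C=C(\O)c4ccccc4)nc(Cl)nc31)[C@H](O)[C@@H]2O` gives 30%, which stands beyond the scatter above compound 1.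

Compound 4 `CNC(=O)[C@@]12C[C@@H]1[C@@H](n1cnc3cnc(C#Cc4ccc(F)c(F)c4)nc31)[C@H](O)[C@@H]2O` has not yet been measured. It differs from compound 1 in a single place: 2-(3,4-difluorophenyl)ethynyl in place of 2-hydroxy-2-(pyrazin-2-yl)ethenyl on an aromatic carbon. The group that leaves carries one hydrogen-bond donor and three hydrogen-bond acceptors; the group that enters carries none of either, and brings a triple bond in place of the double bond.

Going by the values given here, no pair of measured compounds isolates this change, so the size of the step from compound 1 to compound 4 cannot be read directly. Compound 2, which bears a phenylethynyl group at the same aromatic carbon, gives 15%, which sits within the scatter of compound 1 at 14%. On that basis the step of a number 4 percentage points higher from compound 1 to compound 4 (within the scatter) is expected to be small, with no clear direction beyond the scatter. For compound 4 the estimate in this assay is 18%, with an expected range from 5% to 35%.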

Compound 4, a percentage reported as inhibition, at one concentration (the size of the read-out at that concentration, not a potency): 17%
Compound 4: the middle estimate sits 1 percentage points above what was measured, and the stated range covers the measured number.
By their numbers in this assay, from the lowest: compounds 1, 2 and 4 (each within the scatter of the next); then compound 3.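

In this assay, going by these compounds alone, the one-place exchange of 2-hydroxy-2-(pyrazin-2-yl)ethenyl for 2-(3,4-difluorophenyl)ethynyl gives a number 3 percentage points higher from compound 1 to compound 4 (within the scatter) and is the only step here that isolates a change at this aromatic carbon between two ring nitrogen atoms. At the concentration tested, the number at this position therefore cannot be told apart when a group with a hydrogen-bond donor and hydrogen-bond acceptors gives way to one with neither, and when a triple bond stands in place of the double bond. Nothing available explains why the two numbers stay within the scatter of each other.

The compounds shown leave open what the pyrazinyl ring, the hydroxyl group, the two fluorine atoms and the triple bond each contribute alone, as the single step changes them together and their separate effects cannot be read. They also leave open how this assay would read with an amine, a carboxylic acid or a longer saturated chain at this aromatic carbon on the core of compound 1.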